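Replacing 1H-indazol-4-yl with oxan-4-yl

This account rests on a few compounds, and the source may have more. Where it says the series, first, only, none or still open, it means among the compounds named here.

Among the compounds with values here, in a physicochemical assay for solubility (a higher number here means a more soluble compound, a lower number a less soluble compound), compound 2 (`CNC(=O)c1cc(C(=O)NC2CC2)cn(Cc2cccc3[nH]ncc23)c1=O`) gives 10 ug/mL and holds the lower of the two numbers so far, against compound 1 (`CNC(=O)c1cc(C(=O)NC2CC2)cn(Cc2cccc(OC)c2)c1=O`) at 79 ug/mL in the same test. Compound 3 (`CNC(=O)c1cc(C(=O)NC2CC2)cn(CC2CCOCC2)c1=O`) carries oxan-4-yl in place of 1H-indazol-4-yl on a saturated chain carbon bound to an aromatic nitrogen. Within the data shown here, the only measured step at this place is a 7.9-fold lower number from compound 1 to compound 2 (0.90 log units; beyond the scatter) and lies beyond the scatter. Going by that single step, a rise of similar size is expected in this assay (a 10-fold higher number from compound 2 to compound 3 (1.00 log units; beyond the scatter)). The estimate for compound 3 is 100 ug/mL (30 ug/mL to 350 ug/mL).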

Compound 3, solubility: >= 165 ug/mL
Compound 3 was reported as a limit; the forecaster's own chance of this, stated with the estimate: 5%; at least 1.6-fold (0.21 log units) between middle value and limit.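

In this assay, compound 3 is reported only as a limit: the limit of >= 165 ug/mL in this assay, at which 1 of the 3 values shown sits. Even so, oxan-4-yl, a non-aromatic ring, gives the highest number of the three at this place, with an at least 16-fold higher number from compound 2 to compound 3 (1.21 log units; beyond the scatter) and an at least 2.0-fold higher number from compound 1 to compound 3 (0.31 log units; beyond the scatter). Going by these compounds, both steps lie beyond the scatter, so a high number here does not need an aromatic group, though their full size stays unknown.

The compounds shown leave open how much of the rise goes with the ring oxygen, which a plain cyclohexyl ring would test. On these data alone, a piperidin-4-yl ring, which carries an amine, also remains open.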